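Phenyl on the furan of compound 2: expected growth inhibition

The compounds below may be only part of what the source reports. "The series", "measured", "known", "first", "only" and "open" are said of these compounds alone.

Of the compounds shown here, two have numbers so far. Compound 1 `N#C/C(=C\c1c[nH]c2ccccc12)C(=O)c1c[nH]c2ccccc12` and compound 2 `COc1ccc(CNC(=O)/C(C#N)=C/c2ccco2)cc1` share the nitrile-bearing acrylamide-type linkage but differ widely elsewhere. In a functional assay on SMA cells (Homo sapiens) for inhibition, read by MTT assay, with a stated time of 72 h (a higher number here means a weaker inhibitor of growth, a lower number a stronger inhibitor of growth), compound 1 gives 15000 nM. In this assay compound 2 gives 33000 nM, the highest of the two numbers; compound 1 is its nearest neighbour, and the gap between the two lies beyond the scatter of the assay.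

Compound 3 `COc1ccc(CNC(=O)/C(C#N)=C/c2ccc(-c3ccccc3)o2)cc1` is not yet measured. It differs from compound 2 by phenyl in place of hydrogen on an aromatic carbon of the five-membered ring with one oxygen, next to the ring oxygen. Within the data shown here, no measured pair shows this change, so the size of the step is not known from the data.

The step is expected to be modest and towards a lower number, a 2.2-fold lower number from compound 2 to compound 3 (0.34 log units; beyond the scatter). Compound 3 is therefore estimated at 15000 nM, within 4000 nM to 60000 nM.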

Compound 3, concentration for 50% growth inhibition: > 100000 nM
Compound 3 ended at the assay's limit; the forecaster's own chance of this, stated with the estimate: 15%; middle value at least 6.6-fold (0.82 log units) away from the limit.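

The value of > 100000 nM for compound 3 in this assay is a limit of the assay and not a number: the limit of > 100000 nM in this assay, at which 1 of the 3 values shown sits. Phenyl in place of hydrogen on this aromatic carbon, next to the ring oxygen, gives an at least 3.0-fold higher number from compound 2 to compound 3 (0.48 log units; beyond the scatter). Among these compounds, this is the first readable step, and it shows that this position is not neutral to substitution and that the added phenyl moves growth inhibition in the weaker direction.

A single pair does not show whether this loss belongs to phenyl alone or to any substituent at this position. A methyl group or a phenyl carrying an amine on the same carbon would separate these two readings.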